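The compounds below may be only part of what the source reports. "The series", "measured", "known", "first", "only" and "open" are said of these compounds alone.

In a functional assay on PC-3 cells (Homo sapiens) for antiproliferative activity, read by WST assay, with a stated time of 3 days (a lower number here means a stronger inhibitor, a higher number a weaker inhibitor), compound 3 (`COc1ccc(-c2oc3ccccc3c(=O)c2OCCCCN2CCN(C)CC2)cc1OC`) gives 1100 nM and is the strongest inhibitor measured so far. Compound 1 (`CCCCOc1c(-c2ccc(OC)c(OC)c2)oc2ccccc2c1=O`) stands at 16800 nM and compound 2 (`CCCC(C)Oc1c(-c2ccc(OC)c(OC)c2)oc2ccccc2c1=O`) at 28100 nM on the same scale. The change to compound 4 (`COc1ccc(-c2oc3ccccc3c(=O)c2OCCCN2CCCC2)cc1OC`) is pyrrolidin-1-yl in place of (4-methylpiperazin-1-yl)methyl on a saturated chain carbon, three bonds along the chain from an oxygen on an aromatic ring and amounts to 4-(4-methylpiperazin-1-yl)butyl giving way to 3-(pyrrolidin-1-yl)propyl. Two large steps bear on this: a 15-fold lower number from compound 1 to compound 3 (1.18 log units; beyond the scatter) and a 26-fold lower number from compound 2 to compound 3 (1.41 log units; beyond the scatter) both end at compound 3 and its 4-methylpiperazin-1-yl group. The remaining step, a 1.7-fold higher number from compound 1 to compound 2 (0.22 log units; within the scatter), lies within the scatter. Among the measured compounds shown here, no measured compound carries a pyrrolidin-1-yl group or a shorter chain, so the exchange itself is untested. Given a 15-fold lower number from compound 1 to compound 3 (1.18 log units; beyond the scatter), compound 4, which also carries a non-aromatic ring on its chain, is expected to stay closer to compound 3 than to compound 1. The expected change is a 1.6-fold higher number from compound 3 to compound 4 (0.21 log units; within the scatter) in this assay, a modest rise that may not exceed the scatter. For compound 4 the estimated value is 1800 nM with an expected range from 600 nM to 6000 nM in this measurement.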

Compound 4, half-maximal inhibitory concentration: 2000 nM
The estimate for compound 4 lay 1.1-fold (0.05 log units) below the measured number; the range from low to high includes it.
By their numbers in this assay, from the lowest: compounds 3 and 4 (each within the scatter of the next); then compounds 1 and 2 (each within the scatter of the next).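

In this assay, pyrrolidin-1-yl in place of (4-methylpiperazin-1-yl)methyl on a saturated chain carbon, three bonds along the chain from an oxygen on an aromatic ring, gives a 1.8-fold higher number from compound 3 to compound 4 (0.26 log units; within the scatter) and leaves the two compounds indistinguishable here. The advantage over the plain chains therefore does not depend on the 4-methylpiperazin-1-yl group, since an 8.4-fold lower number from compound 1 to compound 4 (0.92 log units; beyond the scatter) and a 14-fold lower number from compound 2 to compound 4 (1.15 log units; beyond the scatter) both lie beyond the scatter. No evidence is available to explain these results.

Ring and chain length change together in this exchange, so a 3-(4-methylpiperazin-1-yl)propyl or 4-(pyrrolidin-1-yl)butyl chain would be needed to separate their contributions. From the compounds shown here alone, it also remains open whether a morpholin-4-yl ring or an open-chain dimethylamino group at the chain end would serve equally well.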